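The source may report more compounds than this note shows. Statements on the series, on what has been measured and on what is new or still open speak of the compounds shown alone.

Among the measured compounds shown here, compound 3 `COc1cc(-c2ccnc3cc(-c4cn(C)c5ccccc45)nn23)cc(OC)c1OC` stands second highest of the three numbers measured so far in a functional assay on HCT-116 cells (Homo sapiens) for inhibition, read by CCK-8 assay, with a stated time of 48 h; on this read-out lower numbers stand for stronger inhibition and higher numbers for weaker inhibition: compound 3 gives 762 nM, compound 1 `COc1cc(-c2ccnc3cc(-c4ccc5cc[nH]c5c4)nn23)cc(OC)c1OC` gives 187 nM, and compound 2 `COc1cc(-c2ccnc3cc(-c4ccc(-c5cnn(C)c5)cc4)nn23)cc(OC)c1OC` gives 2110 nM. For the measured compounds named here, the one single-place step measured so far, a 4.1-fold higher number from compound 1 to compound 3 (0.61 log units; beyond the scatter), shows that exchanging the group on the shared core moves the number by a modest amount. Compound 4 `COc1cc(-c2ccnc3cc(-c4ccc(C(F)(F)F)cc4)nn23)cc(OC)c1OC` differs from compound 3 in one place: 4-(trifluoromethyl)phenyl in place of 1-methyl-1H-indol-3-yl on an aromatic carbon. Going by the values given here, no measured step exchanges a 1-methyl-1H-indol-3-yl for a 4-(trifluoromethyl)phenyl, so the earlier step bears on this one only loosely. Among the compounds with values here, compound 2, whose group also attaches through a six-membered aromatic ring of carbon only, gives the highest number so far, which hints that groups of this shape are tolerated less well. The step to compound 4 is therefore expected to move upward, toward weaker inhibition, by about a 2.0-fold higher number from compound 3 to compound 4 (0.29 log units; within the scatter), because compound 2 gives 2110 nM. Compound 4 is estimated at 1500 nM, with a likely range from 400 nM to 6000 nM.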

Compound 4, half-maximal inhibitory concentration: 1860 nM
Compound 4: middle estimate off by 1.2-fold (0.09 log units), on the low side; low and high end bracket the measured number.
By their numbers in this assay, from the lowest: compound 1; then compound 3; then compounds 4 and 2 (each within the scatter of the next).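

In this assay, exchanging an indole group for the single-ring 4-(trifluoromethyl)phenyl at this position weakens inhibition, with a 2.4-fold higher number from compound 3 to compound 4 (0.39 log units; beyond the scatter) and, starting from the unmethylated indole, a 9.9-fold higher number from compound 1 to compound 4 (1.00 log units; beyond the scatter). What sits on the phenyl ring matters little in this pair, as trifluoromethyl in place of 1-methyl-1H-pyrazol-4-yl gives a 1.1-fold lower number from compound 2 to compound 4 (0.05 log units; within the scatter), so in these four compounds both indole compounds give lower numbers than both phenyl compounds, with none going against this. Nothing available explains why these groups rank this way.

Among the compounds shown here, no compound with an amine or a carboxylic acid on the phenyl ring has been measured. Going by these compounds, whether such a compound would match compound 1 remains open. A 1H-indol-3-yl group would also be needed to separate the effect of the methyl from that of the indole's point of attachment.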